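Aryl Variation on the Triazole Nitrogen of the Shared Core

A few compounds are considered here, and "the series" means these few. Any claim that something is new, unique, unknown or untested is made for them only; others in the source may bear on it.

Compound 3 `Cc1ccc(C)c(-n2nncc2CN2C(=O)C3(C(C#N)=C(N)Oc4c(N)cc5nc6ccccc6nc5c43)c3ccccc32)c1` stands at a limit in a functional assay on HepG2 cells (Homo sapiens) for antiproliferative activity, read by MTT assay, with a stated time of 48 h; a lower number here means a stronger inhibitor, a higher number a weaker inhibitor: its reading, > 50000 nM, is the assay limit and not a number. Among the compounds with values here, the compounds measured so far share the core of compound 3 and differ only in the group carried on the aromatic nitrogen. Compound 1 `Cc1cccc(-n2nncc2CN2C(=O)C3(C(C#N)=C(N)Oc4c(N)cc5nc6ccccc6nc5c43)c3ccccc32)c1` likewise sits at a limit, > 50000 nM. Compound 2 `N#CC1=C(N)Oc2c(N)cc3nc4ccccc4nc3c2C12C(=O)N(Cc1cnnn1-c1ccccc1Cl)c1ccccc12` returns a number, 33500 nM. Two of the three readings therefore rest at the same limit (the limit of > 50000 nM in this assay, at which 2 of the 3 values shown sit). The step of an at least 1.4-fold higher number from compound 2 to compound 3 (0.17 log units; that floor lies within the scatter) leans on that single number; the step that the two limits leave unreadable from compound 1 to compound 3 cannot be read between two limits, and the step of an at least 1.4-fold lower number from compound 1 to compound 2 (0.17 log units; that floor lies within the scatter) stays within the usual scatter.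

Compound 4 `COc1ccc(OC)c(-n2nncc2CN2C(=O)C3(C(C#N)=C(N)Oc4c(N)cc5nc6ccccc6nc5c43)c3ccccc32)c1` is not yet measured; it differs from compound 3 by 2,5-dimethoxyphenyl in place of 2,5-dimethylphenyl on an aromatic nitrogen. The measured steps at this same aromatic nitrogen lie either within the scatter or between limits, so no shift beyond the scatter is expected in this assay for the step of an at least 1.1-fold lower number from compound 3 to compound 4 (0.04 log units; that floor lies within the scatter). Compound 4 is therefore expected to give 45000 nM, with a range from 20000 nM to 100000 nM, most probably reported once more as a limit rather than a number.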

Compound 4, half-maximal inhibitory concentration: 45100 nM
Compound 4: the middle estimate sits 1.0-fold (0.00 log units) below what was measured; the measured number falls inside the stated range.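

In this assay, within the data shown here, this aromatic nitrogen now carries a second group with a number, and a 1.3-fold higher number from compound 2 to compound 4 (0.13 log units; within the scatter) is the first step here read between two numbers rather than against a limit. The 2,5-dimethoxyphenyl group has 2 hydrogen-bond acceptors where 2,5-dimethylphenyl has 0 and 10 heavy atoms where it has 8, yet an at least 1.1-fold lower number from compound 3 to compound 4 (0.04 log units; that floor lies within the scatter) and an at least 1.1-fold lower number from compound 1 to compound 4 (0.04 log units; that floor lies within the scatter) give only floors, and those floors do not reach beyond the scatter. No step at this position reads beyond the scatter, and the step between compound 1 and compound 3 cannot be read, as both sit at a limit: the limit of > 50000 nM in this assay, at which 2 of the 4 values shown sit.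

From the compounds shown here alone, whether an amine or a carboxylic acid on the phenyl ring, or a longer alkyl chain in its place, would move the number beyond the scatter stays open. Also open, going by these compounds, is how far compound 1 and compound 3 really lie from compound 4, since their limits fix only a floor for each step and leave the true size of those steps unknown.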